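This account rests on a few compounds, and the source may have more. Where it says the series, first, only, none or still open, it means among the compounds named here.

Measured so far:
- compound 1, `C=C(CC)C(=O)c1ccc(OCC(=O)Nc2nc3ccccc3s2)c(Cl)c1Cl`: 1500 nM 
- compound 2, `C=C(CC)C(=O)c1ccc(OCC(=O)Nc2ccc3c(c2)C(=O)NC3=O)c(Cl)c1Cl`: 2500 nM 
- compound 3, `C=C(CC)C(=O)c1ccc(OCC(=O)Nc2ccc(C(=O)NC(CCC(=O)OCC)C(=O)OCC)cc2)c(Cl)c1Cl`: 2100 nM 

All three values come from a functional assay on CLL cells (Homo sapiens) for cytotoxicity, read by MTT assay, with a stated time of 48 h; on this read-out lower numbers stand for an effect already at smaller amounts and higher numbers for an effect only at larger amounts of compound. Among them compound 1 gives the smallest number, but compound 3 and compound 2 both sit within the usual scatter of it, so the three cannot be told apart on this read-out. They share one core and differ only in the group attached to the amide-type nitrogen, and that variation has not moved the numbers beyond the scatter.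

Compound 4, `C=C(CC)C(=O)c1ccc(OCC(=O)NO)c(Cl)c1Cl`, is not yet measured. It differs from compound 1 in one place: hydroxy in place of 1,3-benzothiazol-2-yl on an amide-type nitrogen. The group that leaves is a ring system; the group that enters is a single hydroxy with one hydrogen-bond donor and one hydrogen-bond acceptor.

In this assay, since the larger groups on this nitrogen gave near-identical numbers, a step of at most modest size, towards a higher number, is expected: a 2.3-fold higher number from compound 1 to compound 4 (0.37 log units; beyond the scatter). Compound 4 is therefore estimated at 3500 nM, with a range from 1200 nM to 10000 nM.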

Compound 4, half-maximal effective concentration: 4500 nM
For compound 4 the middle estimate is 1.3-fold (0.11 log units) below the measured one; low and high end bracket the measured number.
By their numbers in this assay, from the lowest: compounds 1, 3, 2 and 4 (each within the scatter of the next, the first and the last beyond it).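

In this assay, for the compounds shown here, the amide-type nitrogen had so far carried only large groups that could not be told apart, and this is the first change there to show a step beyond the usual scatter: swapping 1,3-benzothiazol-2-yl for hydroxy gives a 3.0-fold higher number from compound 1 to compound 4 (0.48 log units; beyond the scatter) on this read-out. The step is modest, so compound 4 keeps a measurable effect even though the ring system has gone and a single oxygen stands in its place. Nothing available explains why the number moves with this change.

This one swap removes the ring system and brings in hydroxy together, so the two changes cannot be separated. A methyl, a methoxy, an amine or a plain phenyl on this nitrogen could show whether the number follows the loss of the ring system or the presence of hydroxy.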